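Methoxyacetamidine series: effect of removing the carboxy group

This account rests on a few compounds, and the source may have more. Where it says the series, first, only, none or still open, it means among the compounds named here.

Compound 1 `COCCNC(=N)NCCC(C)C`: 4%
Compound 2 `COCC(=N)NCCC[C@H](N)C(=O)O`: 75%

In an assay on isolated protein for inhibition of Nitric oxide synthase, inducible (Homo sapiens), read by spectrophotometry, using NADPH, tested at 1 mM, in the presence of a further agent that is not named here (a higher number here means more inhibition at the concentration tested (going by the name of the read-out), a lower number less inhibition), compound 2 gives the higher of the two numbers; compound 1 gives 4%, and the gap between them is beyond the scatter. Within the data shown here, no step between measured compounds differing in one place is available. Compound 3 `COCC(=N)NCCCCN` is not yet measured; it differs from compound 2 as hydrogen in place of carboxy on a saturated chain carbon bound to an amine nitrogen and a saturated chain carbon. Among the measured compounds shown here, with only two measured compounds, the step from compound 2 to compound 3 is expected to be a loss of moderate size, a number 20 percentage points lower from compound 2 to compound 3 (beyond the scatter), beyond the scatter. Compound 3 is therefore estimated at 55%, within 25% to 80%.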

Compound 3, a percentage reported as inhibition, at one concentration (the size of the read-out at that concentration, not a potency): 42%
Beside the measured number, compound 3's estimate is 13 percentage points above it; low and high end bracket the measured number.
By their numbers in this assay, from the lowest: compound 1; then compound 3; then compound 2.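

In this assay the step of a number 33 percentage points lower from compound 2 to compound 3 (beyond the scatter) isolates carboxy on a saturated chain carbon bound to an amine nitrogen and a saturated chain carbon as a contributor to the reading, while compound 3 with 42% still shows inhibition without that group. The earlier pair differed in more than one place and could not separate this change. Nothing at hand accounts for the size of this loss.

As far as these compounds go, whether a methyl ester or a primary amide on that carbon would stay closer to compound 2 remains open. So does the effect of a longer chain in compound 3.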